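The compounds below may be only part of what the source reports. "The series", "measured", "known", "first", "only" and "open" are said of these compounds alone.

Of the compounds shown here, three have so far been measured in a functional assay on NCI-H3122 cells (Homo sapiens) for antiproliferative activity, read by MTT assay, with a stated time of 48 h; a lower number here means a stronger inhibitor, a higher number a weaker inhibitor. Compound 1 `COc1cccc(CNC(=O)c2cccc(C(C)Oc3cccnc3Nc3cnn(C)c3)c2)c1` gives 49400 nM, compound 2 `Cc1ccc(CNC(=O)c2cccc(C(C)Oc3cccnc3Nn3cnnc3)c2)cc1` gives 23700 nM, and compound 3 `COc1ccc(CNC(=O)c2cccc(C(C)Oc3ccnc(Nc4cnn(C)c4)c3)c2)cc1OC` gives 38500 nM. Compound 3 lies close to both of the others: its gap to compound 1 and its gap to compound 2 each fall within the usual scatter, so compound 3 cannot be called stronger or weaker than either. Compound 4 `CC(Oc1ccnc(Nc2cnn(C)c2)c1)c1cccc(C(=O)NCc2ccc(C#N)cc2)c1` has not yet been measured. It differs from compound 3 in one place: 4-cyanophenyl in place of 3,4-dimethoxyphenyl on a saturated chain carbon bound to an amide-type nitrogen. Among the compounds with values here, no single-change step between measured compounds is available to guide this, so no shift beyond the scatter is expected in either direction, and the step of a 1.0-fold higher number from compound 3 to compound 4 (0.02 log units; within the scatter) is only an estimate. Compound 4 is expected to give about 40000 nM in this assay, with a likely range from 15000 nM to 100000 nM.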

Compound 4, half-maximal inhibitory concentration: 35100 nM
Compound 4: middle estimate off by 1.1-fold (0.06 log units), on the high side; the measured number falls inside the stated range.
By their numbers in this assay, from the lowest: compounds 2, 4, 3 and 1 (each within the scatter of the next, the first and the last beyond it).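

In this assay, within the data shown here, the step of a 1.1-fold lower number from compound 3 to compound 4 (0.04 log units; within the scatter) stays within the scatter, the first direct reading at this position. A 3,4-dimethoxyphenyl and a 4-cyanophenyl on a saturated chain carbon bound to an amide-type nitrogen cannot be told apart here, even though the two methoxy groups give way to a single nitrile. No supporting data bear on why this is so.

On these data alone, whether an amine or a carboxylic acid on that phenyl ring, or a longer chain leading to it, would shift the number beyond the scatter stays open.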